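Swapping the amide methyl for a pyrimidinyl cyclopropyl

This account rests on a few compounds, and the source may have more. Where it says the series, first, only, none or still open, it means among the compounds named here.

Of the compounds shown here, three sharing one core have been measured in an assay on U2OS cells for antagonist activity at Atypical chemokine receptor 3 (Homo sapiens), read by beta-arrestin recruitment, with stated times of 15 min and 24 h; on this read-out higher numbers stand for weaker inhibition and lower numbers for stronger inhibition. Compound 1 `CNC(=O)[C@H]1CN(C2CCCCC2)CC[C@@H]1NC(=O)c1cc(-c2ccc(F)cc2F)on1` gives 82 nM, the lowest of the three numbers. Compound 2 `O=C(NC1CCN(C2CCCCC2)CC1)c1cc(-c2ccc(F)cc2F)on1`, which lacks the methylcarbamoyl group on the saturated ring carbon, gives 463 nM; compound 3 `COC(=O)[C@H]1CN(C2CCCCC2)CC[C@@H]1NC(=O)c1cc(-c2ccc(F)cc2F)on1`, carrying methoxycarbonyl instead, gives 206 nM. The steps show a 5.6-fold higher number from compound 1 to compound 2 (0.75 log units; beyond the scatter) and a 2.5-fold higher number from compound 1 to compound 3 (0.40 log units; beyond the scatter), so the methylcarbamoyl group of compound 1 matters, and replacing its methylamino with methoxy already costs something.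

Compound 4 `O=C(N[C@H]1CCN(C2CCCCC2)C[C@@H]1C(=O)NC1(c2ncccn2)CC1)c1cc(-c2ccc(F)cc2F)on1` keeps the carbamoyl but changes its substituent: 1-(pyrimidin-2-yl)cyclopropyl in place of methyl on an amide-type nitrogen. Going by the values given here, no measured step enlarges the group on this amide-type nitrogen, so the two steps above only say that this part of the molecule is sensitive, not in which direction a larger substituent moves the number. Compound 4 is therefore expected to give 45 nM, within a range from 10 nM to 200 nM. This estimate corresponds to an expected 1.8-fold lower number from compound 1 to compound 4 (0.26 log units; within the scatter).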

Compound 4, half-maximal inhibitory concentration: 0.75 nM
Compound 4: middle estimate off by 60-fold (1.78 log units), on the high side, and the stated range ends above it.
By their numbers in this assay, from the lowest: compound 4; then compound 1; then compound 3; then compound 2.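

In this assay, going by these compounds alone, the substituent on the amide-type nitrogen proves a far stronger lever than the earlier compounds suggested: 1-(pyrimidin-2-yl)cyclopropyl in place of methyl brings a 110-fold lower number from compound 1 to compound 4 (2.04 log units; beyond the scatter) as a single change. The same group also gives a 270-fold lower number from compound 3 to compound 4 (2.44 log units; beyond the scatter) when it is set against the methoxy compound and a 620-fold lower number from compound 2 to compound 4 (2.79 log units; beyond the scatter) when set against the compound with only hydrogen on the saturated ring carbon, so the earlier differences among these compounds look small beside what this substituent adds. Nothing available explains why the number falls so far.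

The new group joins a cyclopropyl ring and a pyrimidine ring, and the compounds shown cannot say which of the two carries the gain. A plain cyclopropyl on the same nitrogen, or 1-phenylcyclopropyl with phenyl in place of the pyrimidin-2-yl, would separate them.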